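Replacing 2-fluorophenyl with 4-acetylphenyl on a shared core

The source may report more compounds than this note shows. Statements on the series, on what has been measured and on what is new or still open speak of the compounds shown alone.

Compound 1 `Nc1nc(N)c2cc(CSC(=S)N3CCN(c4ccc(O)cc4)CC3)ccc2n1`: 5980 nM
Compound 2 `Nc1nc(N)c2cc(CSC(=S)N3CCN(c4ccc(Cl)cc4)CC3)ccc2n1`: 7380 nM
Compound 3 `Nc1nc(N)c2cc(CSC(=S)N3CCN(c4ccccc4F)CC3)ccc2n1`: "not determined" (no result reported)

These three compounds share one core and differ only in the aromatic group on the amine nitrogen. They were examined in a functional assay on HCT-116 cells (Homo sapiens) for antiproliferative activity, read by MTT assay, with a stated time of 72 h; on this read-out lower numbers stand for stronger inhibition and higher numbers for weaker inhibition. Compound 3 has no standing on the numbers, since no result was reported for it, so it gives no value from which to count a step.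

Compound 4 `CC(=O)c1ccc(N2CCN(C(=S)SCc3ccc4nc(N)nc(N)c4c3)CC2)cc1` is the next member of the series. Its structure departs from that of compound 3 as follows: 4-acetylphenyl in place of 2-fluorophenyl on an amine nitrogen in a ring. In words, 4-acetylphenyl stands in place of 2-fluorophenyl on an amine nitrogen in a ring.

Going by the values given here, only one measured step bears on this change, and it is an indirect guide, as it involves neither the acetyl nor the fluoro group. Chloro in place of hydroxy on an aromatic carbon gives a 1.2-fold higher number from compound 1 to compound 2 (0.09 log units; within the scatter). Among the compounds with values here, with so small a step as the only evidence, no step of a particular size or direction can be expected for the new group. The expectation therefore rests on the level shared by compound 1 at 5980 nM and compound 2 at 7380 nM.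

For compound 4 the expected value in this assay is about 6500 nM, with an estimated range from 2500 nM to 17000 nM.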

Compound 4, half-maximal inhibitory concentration: 8260 nM
Compound 4: middle estimate off by 1.3-fold (0.10 log units), on the low side; the range from low to high includes it.
By their numbers in this assay, from the lowest: compounds 1, 2 and 4 (each within the scatter of the next).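

In this assay, acetyl in place of chloro gives a 1.1-fold higher number from compound 2 to compound 4 (0.05 log units; within the scatter) and acetyl in place of hydroxy gives a 1.4-fold higher number from compound 1 to compound 4 (0.14 log units; within the scatter) on the shared core. With compound 4 there are now three groups on the aromatic ring carried by the amine nitrogen, and hydroxy, chloro and acetyl all give numbers within the scatter of one another, so the new 4-acetylphenyl, with its added carbonyl and its hydrogen-bond acceptor, separates compound 4 from neither compound 1 nor compound 2. Nothing measured here offers an explanation for how alike these numbers are.

The steps that lead from compound 3 cannot be read, as it has no number, so the exchange of 2-fluorophenyl for 4-acetylphenyl itself remains unmeasured as a step, and the compounds shown say nothing about how a group on the aromatic ring other than at the site held by acetyl would compare. Going by these compounds, it also stays open whether an amine or a carboxylic acid in place of the acetyl, or a longer chain in place of the whole aromatic group, would move the number beyond the scatter.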